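Halogen swap at the indole ring: iodo for fluoro

The source may hold more compounds than are shown below. What is called first, only, known or untested is meant among the compounds shown, and "the series" means these compounds.

Measured compounds in an assay on isolated protein for inhibition of Indoleamine 2,3-dioxygenase 1 (Homo sapiens), read by HPLC, with a stated time of 60 min, in the presence of a further agent that is not named here; on this read-out higher numbers stand for weaker inhibition and lower numbers for stronger inhibition:
- compound 1 `COc1ccccc1Sc1c[nH]c2ccc(Cl)cc12`: 17500 nM
- compound 2 `Cc1ccccc1Sc1c[nH]c2ccc(Cl)cc12`: 21000 nM
- compound 3 `COc1ccccc1Sc1c[nH]c2ccc(F)cc12`: 32000 nM

Compound 3 sits at the upper end of the three numbers, but its gap to each of the others is within the scatter: the step of a 1.8-fold higher number from compound 1 to compound 3 (0.26 log units; within the scatter) is small, and the values of compound 2 and compound 3 lie close together. The other change so far, a 1.2-fold higher number from compound 1 to compound 2 (0.08 log units; within the scatter), is also within the scatter. No step beyond the scatter has been seen in this small set.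

Compound 4 `COc1ccccc1Sc1c[nH]c2ccc(I)cc12` differs from compound 3 by iodo in place of fluoro on an aromatic carbon. Within the data shown here, the only step that bears on this change is a 1.8-fold higher number from compound 1 to compound 3 (0.26 log units; within the scatter), a halogen exchange at the same position that moved the number only within the scatter. On that basis no step beyond the scatter is expected in this assay for iodo in place of fluoro, with a slight lean toward a lower number, since compound 1 with chloro gave 17500 nM.

Compound 4 is therefore expected to give about 14000 nM, with a range from 5000 nM to 40000 nM. This estimate means an expected step of a 2.3-fold lower number from compound 3 to compound 4 (0.36 log units; beyond the scatter).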

Compound 4, half-maximal inhibitory concentration: 45000 nM
For compound 4 the middle estimate is 3.2-fold (0.51 log units) below the measured one, outside the stated range (above it).
By their numbers in this assay, from the lowest: compounds 1, 2, 3 and 4 (each within the scatter of the next, the first and the last beyond it).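

At this aromatic carbon of the shared core, this assay now shows a halogen exchange that goes beyond the scatter, modest in size, for iodo in place of chloro (a 2.6-fold higher number from compound 1 to compound 4 (0.41 log units; beyond the scatter)). Iodo in place of fluoro stays within the scatter (a 1.4-fold higher number from compound 3 to compound 4 (0.15 log units; within the scatter)), so of the three halogens shown only chloro and iodo can be told apart, while fluoro lies within the scatter of both. No measurement is available that bears on what lies behind this small difference.

The compounds shown leave open whether the step from chloro to iodo carries over when methyl stands in place of methoxy, as in compound 2. They also leave open how a non-halogen group at this carbon, such as an amine, a nitrile or a carboxylic acid, would read against compound 1 (17500 nM), and whether any such group would give a step beyond the scatter toward stronger inhibition.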